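Swapping the amide substituent on a dimethylamino analogue

A few compounds are considered here, and "the series" means these few. Any claim that something is new, unique, unknown or untested is made for them only; others in the source may bear on it.

Compound 2 `Cc1ccc2nc(N(C)C)nc(NCc3ccc(C(=O)N[C@H]4C[C@@H]4c4ccccc4)cc3)c2c1` was run in a functional assay on SW480 cells (Homo sapiens) for inhibition, read by luminescence and resazurin assay, with a stated time of 3 days (a lower number here means a stronger inhibitor, a higher number a weaker inhibitor), and gives 2400 nM. That is the higher of the two numbers shown, yet compound 1 `CCCNc1nc(NCc2ccc(C(=O)Nc3ccc(Cl)nc3)cc2)c2cc(C)ccc2n1`, which gives 2100 nM, sits within the scatter of it. Compound 3 `Cc1ccc2nc(N(C)C)nc(NCc3ccc(C(=O)Nc4ccc(Cl)nc4)cc3)c2c1` has not been measured; it differs from compound 2 by 6-chloropyridin-3-yl in place of 2-phenylcyclopropyl on an amide-type nitrogen. Going by the values given here, no measured pair covers this change, but compound 1 already carries the 6-chloropyridin-3-yl amide and its 2100 nM lies close to compound 2, so no step beyond the scatter is expected in this assay. Compound 3 is therefore expected to give 2200 nM, within 900 nM to 5500 nM. The expected step is a 1.1-fold lower number from compound 2 to compound 3 (0.04 log units; within the scatter).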

Compound 3, half-maximal inhibitory concentration: 1100 nM
For compound 3 the middle estimate is 2.0-fold (0.30 log units) above the measured one; low and high end bracket the measured number.
By their numbers in this assay, from the lowest: compounds 3, 1 and 2 (each within the scatter of the next, the first and the last beyond it).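

Going by these compounds alone, on the amide-type nitrogen of the dimethylamino compounds, 6-chloropyridin-3-yl in place of 2-phenylcyclopropyl gives a modest change beyond the scatter in this assay (a 2.2-fold lower number from compound 2 to compound 3 (0.34 log units; beyond the scatter)), the first step that can be read at this position. With the 6-chloropyridin-3-yl amide held fixed, dimethylamino in place of propylamino on an aromatic carbon stays within the scatter (a 1.9-fold lower number from compound 1 to compound 3 (0.28 log units; within the scatter)). Nothing available explains either result.

The compounds shown leave open how a plain phenyl or a benzyl group would read on that nitrogen. They also leave open how a morpholine or a longer chain would read in place of dimethylamino.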